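Series notes: amide nitrogen swap from compound 2

The compounds below may be only part of what the source reports. "The series", "measured", "known", "first", "only" and "open" are said of these compounds alone.

The series is followed in a physicochemical assay for lipophilicity, read by HPLC, at pH 3.0; on this read-out higher numbers stand for higher lipophilicity and lower numbers for lower lipophilicity. Compound 1 `NCc1csc(NC(=O)c2ccn[nH]2)n1` gives 0, and compound 3 `NCc1csc(NC(=O)c2ccccc2)n1` gives 0.7. Compound 2 `CC(C)(C)c1cc(C(=O)Nc2ccncc2)n(Cc2ccccc2)n1` gives 2.6, the highest of the three numbers; its gap to compound 3 and its larger gap to compound 1 both lie beyond the usual scatter. Compound 4 `CNCc1csc(NC(=O)c2cc(C(C)(C)C)nn2Cc2ccccc2)n1` has not yet been measured in this assay.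

Compound 4 differs from compound 2 in one place: 4-((methylamino)methyl)-1,3-thiazol-2-yl in place of pyridin-4-yl on an amide-type nitrogen. Within the data shown here, no single-change pair among the measured compounds gives a direct read on this swap; compounds 1 and 3 carry the related aminomethyl thiazole but a different acyl part, so their numbers only frame the question.

A modest decrease is expected in this assay, since compound 1 gives 0 and compound 3 gives 0.7 while the acyl part of compound 4 is that of compound 2. Compound 4 is estimated at 2.2, with a range from 1.4 to 3, which means an expected step of a number 0.40 log units lower from compound 2 to compound 4 (beyond the scatter).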

Compound 4, distribution coefficient: 2.6
For compound 4 the middle estimate is 0.40 log units below the measured one; the range from low to high includes it.
By their numbers in this assay, from the lowest: compound 1; then compound 3; then compounds 2 and 4 (each within the scatter of the next).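

In this assay the read-out shows no change at the digits printed from compound 2 to compound 4 (within the scatter) with 4-((methylamino)methyl)-1,3-thiazol-2-yl in place of pyridin-4-yl on an amide-type nitrogen. Among these compounds, this is the first direct read on this position, and it shows that the read-out does not separate the two groups with this acyl part, although the entering group brings a five-membered aromatic ring with 2 hetero atoms and a hydrogen-bond donor that pyridin-4-yl lacks. No measurement at hand accounts for this outcome.

The compounds shown do not separate the contribution of the 1,3-thiazol-2-yl ring from that of the methylamino part of the side chain. Open questions are how the read-out would respond with a dimethylamino group or a hydroxyl group in place of methylamino, and with an unsubstituted 1,3-thiazol-2-yl group on the same nitrogen.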